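Amine replacements of the hydroxy group in a carbamate series

This account rests on a few compounds, and the source may have more. Where it says the series, first, only, none or still open, it means among the compounds named here.

Values in a functional assay on NCI-H358 cells (Homo sapiens) for antiproliferative activity, read by sulforhodamine B assay, with a stated time of 48 h, tested at 10 uM; a higher number here means more inhibition at the concentration tested (going by the name of the read-out), a lower number less inhibition:
compound 1 `CCCCCCCCCCCCCC[C@H](OCOC)[C@H](CO)NC(=O)OC(C)(C)C`: 18.4%
compound 2 `CCCCCCCCCCCCCC[C@H](OCOC)[C@H](CN(CC)CC)NC(=O)OC(C)(C)C`: 15%
compound 3 `CCCCCCCCCCCCCC[C@H](OCOC)[C@H](CN(C(C)C)C(C)C)NC(=O)OC(C)(C)C`: 26.6%

Compound 1 stands second highest of the three numbers. Its step to compound 2 is a number 3.4 percentage points lower from compound 1 to compound 2 (within the scatter) and its step to compound 3 is a number 8.2 percentage points higher from compound 1 to compound 3 (within the scatter); between the two amines the step is a number 11.6 percentage points higher from compound 2 to compound 3 (beyond the scatter).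

Compound 4 `CCCCCCCCCCCCCC[C@H](OCOC)[C@H](CN1CCN(C)CC1)NC(=O)OC(C)(C)C` is not yet measured. The change from compound 1 is 4-methylpiperazin-1-yl in place of hydroxy on a saturated chain carbon, two bonds along the chain from an amide-type nitrogen. Among the measured compounds shown here, the steps that bear on it, compound 1 to compound 2 and compound 1 to compound 3, both exchange the hydroxy for an amine and both stay within the scatter, so no step beyond the scatter is expected here either; the expected step is a number 1.6 percentage points higher from compound 1 to compound 4 (within the scatter). For compound 4 the estimate in this assay is 20%, with a range from 8% to 34%.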

Compound 4, a percentage reported as inhibition, at one concentration (the size of the read-out at that concentration, not a potency): 18.9%
The estimate for compound 4 lay 1.1 percentage points above the measured number, within the range that was stated.
By their numbers in this assay, from the lowest: compounds 2, 1, 4 and 3 (each within the scatter of the next, the first and the last beyond it).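

In this assay the ring amine 4-methylpiperazin-1-yl, in place of hydroxy on this saturated chain carbon, gives a number 0.5 percentage points higher from compound 1 to compound 4 (within the scatter) and so stays level with the alcohol, as the open-chain amines did. It also does not separate from either open-chain amine, with a number 3.9 percentage points higher from compound 2 to compound 4 (within the scatter) and a number 7.7 percentage points lower from compound 3 to compound 4 (within the scatter), although those two amines differ from each other beyond the scatter. Still open, from the compounds shown here alone, is whether a morpholin-4-yl group, a primary amine or a carboxylic acid at this place would stay within the same band. No evidence on hand bears on the cause of these numbers.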